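Swapping methyl for fluoro in a cytotoxicity series

The compounds below may be only part of what the source reports. "The series", "measured", "known", "first", "only" and "open" are said of these compounds alone.

compound 1 `O=c1cc([Se]c2ccccc2)n(COCCO)c(=O)[nH]1`: > 100000 nM (a limit)
compound 2 `Cc1c([Se]c2ccccc2)n(COCCO)c(=O)[nH]c1=O`: > 200000 nM (a limit)

In a functional assay (Homo sapiens) for cytotoxicity (a lower number here means a stronger inhibitor, a higher number a weaker inhibitor), compound 1 gives > 100000 nM as a limit of the assay and not a number. Compound 2 gives > 200000 nM as a limit too, so it stands without an exact value.

Compound 3 `O=c1[nH]c(=O)n(COCCO)c([Se]c2ccccc2)c1F` differs from compound 2 by a single change, fluoro in place of methyl on an aromatic carbon. Going by the values given here, only one measured step bears on this change. That step (a step that the two limits leave unreadable from compound 1 to compound 2) puts methyl in place of hydrogen on the same carbon, and its size cannot be read, so it offers no size to carry over. Neither measured compound reached an exact number in this assay and that leaves no basis for a direction. The step (an at least 1.3-fold lower number from compound 2 to compound 3 (0.12 log units; that floor lies within the scatter)) is therefore expected to stay within the usual scatter. Compound 3 is estimated at 150000 nM with an expected range from 50000 nM to 400000 nM, and a limit rather than an exact number is expected for it as well.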

Compound 3, half-maximal inhibitory concentration: > 100000 nM
Compound 3: a limit, no number; the forecaster's own chance of this, stated with the estimate: 70%; the middle value lies beyond the limit too.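

In this assay compound 3 gives > 100000 nM, a limit of the assay and not a number. Going by these compounds alone, compound 1, compound 2 and compound 3 all stand at limits, so no step among them can be read. From the compounds shown here alone, whether hydrogen, methyl or fluoro on that aromatic carbon makes any difference to cytotoxicity stays open.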